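The compounds below may be only part of what the source reports. "The series", "measured", "known", "first", "only" and "open" are said of these compounds alone.

Measured so far in an ADME assay on the whole organism (strain Han-Wistar) for pharmacokinetics, with Rattus norvegicus as the target, read by LC-MS, at a dose of 2 mg/kg by the oral route; a higher number here means more compound in the circulation at the dose given, a lower number less compound in the circulation:
compound 1 `Cc1cc(C)n(-c2ccc(Cl)c(C(=O)NC(=O)Nc3nc4ccc(S(=O)(=O)CCCN5CCN(C)CC5)cc4s3)c2)n1`: 78 nM
compound 2 `CN1CCN(CCCS(=O)(=O)c2ccc3nc(NC(=O)NC(=O)c4cc(-n5cccc5)ccc4Cl)sc3c2)CC1`: 580 nM
compound 3 `Cc1ccn(-c2ccc(Cl)c(C(=O)NC(=O)Nc3nc4ccc(S(=O)(=O)CCCN5CCN(C)CC5)cc4s3)c2)n1`: 410 nM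

Compound 2 stands highest of the three numbers in this assay. Its gap to compound 3 is within the scatter, so the two cannot be ranked; its gap to compound 1 is beyond the scatter, as the step of a 7.4-fold higher number from compound 1 to compound 2 (0.87 log units; beyond the scatter) shows. The step of a 5.3-fold higher number from compound 1 to compound 3 (0.72 log units; beyond the scatter) and the step of a 1.4-fold lower number from compound 2 to compound 3 (0.15 log units; within the scatter) complete the picture: the two methyl groups of compound 1 go with the lowest number, while a single methyl or none leaves the number unchanged within the scatter.

Compound 4 `CN1CCN(CCCS(=O)(=O)c2ccc3nc(NC(=O)NC(=O)c4cc5c(ccn5C)cc4Cl)sc3c2)CC1` is not yet measured. It differs from compound 2 in one place: 5-chloro-1-methyl-1H-indol-6-yl in place of 2-chloro-5-(1H-pyrrol-1-yl)phenyl on a carbonyl carbon. Going by the values given here, none of the measured steps bears directly on this change, since all three concern substitution on the five-membered ring rather than its fusion to the six-membered ring. The nearest guide is the step of a 5.3-fold higher number from compound 1 to compound 3 (0.72 log units; beyond the scatter), where a methyl on the five-membered ring went with a lower number, and compound 4 carries a methyl on its five-membered ring. On that basis a small decrease is expected for compound 4, a 1.7-fold lower number from compound 2 to compound 4 (0.22 log units; within the scatter), with the direction uncertain. The estimate for compound 4 in this assay is 350 nM, in the range 100 nM to 1200 nM.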

Compound 4, maximal plasma concentration: 300 nM
Beside the measured number, compound 4's estimate is 1.2-fold (0.07 log units) above it; the measured number falls inside the stated range.
By their numbers in this assay, from the lowest: compound 1; then compounds 4, 3 and 2 (each within the scatter of the next).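

In this assay, the 5-chloro-1-methyl-1H-indol-6-yl group on the carbonyl carbon takes the place of the 2-chloro-5-(1H-pyrrol-1-yl)phenyl group with a 1.9-fold lower number from compound 2 to compound 4 (0.29 log units; within the scatter), so this exchange cannot be told apart from repeat-measurement scatter. The entering group has the same kinds of aromatic ring and the same hydrogen-bond donor and acceptor counts as the group it replaces, but fewer heavy atoms, and for this pair a five-membered ring attached through its nitrogen is not needed to give a number in this range. Nothing at hand explains why the two groups give numbers within the scatter of each other.

The compounds shown leave open what the methyl on the indole contributes, as the 5-chloro-1H-indol-6-yl group, with hydrogen in place of that methyl, would be the direct comparison with compound 4. They also leave open whether the chlorine matters at this position, which a fluorine or a hydrogen in its place on the same group would test.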